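A few compounds are considered here, and "the series" means these few. Any claim that something is new, unique, unknown or untested is made for them only; others in the source may bear on it.

Measured compounds:
compound 1, `CC(C)CCn1nc(-c2cccs2)c(O)c(C2=NS(=O)(=O)c3cc(N(C(C)C)S(C)(=O)=O)ccc3N2)c1=O` — "not determined" (no result reported)
compound 2, `CCC(C)CCn1nc(-c2cccs2)c(O)c(C2=NS(=O)(=O)c3cc(NS(C)(=O)=O)ccc3N2)c1=O` — > 1000 nM

In an ADME assay on Huh-7 cells (Homo sapiens) for cytotoxicity, with a stated time of 72 h (on this read-out lower numbers stand for higher toxicity in this test and higher numbers for lower toxicity in this test), compound 1 has no reported result, "not determined" (no result reported). Compound 2 reaches only a limit of this assay, > 1000 nM, and so stands at the limit of > 1000 nM in this assay, at which 1 of the 2 values shown sits. Compound 3, `CS(=O)(=O)Nc1ccc2c(c1)S(=O)(=O)N=C(c1c(O)c(-c3cccs3)nn(CCC3CCC3)c1=O)N2`, is not yet measured; it differs from compound 2 by cyclobutyl in place of sec-butyl on a saturated chain carbon, two bonds along the chain from an aromatic nitrogen. Going by the values given here, no step between two measured numbers exists to lean on, so any change in this assay is expected to stay within the scatter, in no fixed direction. Compound 3 is therefore estimated at 1500 nM, with a range from 700 nM to 4000 nM. The estimated step is a step that the limit leaves unreadable from compound 2 to compound 3.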

Compound 3, half-maximal cytotoxic concentration: > 1000 nM
Compound 3 gave a limit, no number; the forecaster's own chance of this, stated with the estimate: 70%; the middle value lies beyond the limit too.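

No step can be read from compound 2 to compound 3, as both results in this assay are limits and not numbers: the limit of > 1000 nM in this assay, at which 2 of the 3 values shown sit.

The compounds shown leave open whether cyclobutyl in place of sec-butyl changes the cytotoxic concentration at all.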